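Moving the Halogen: Expected Tolerance of Compound 4

The source may hold more compounds than are shown below. What is called first, only, known or untested is meant among the compounds shown, and "the series" means these compounds.

Of the compounds shown here, three sharing one core have been tested in an ADME assay on MT4 cells (Homo sapiens) for cytotoxicity, read by MTT assay; a higher number here means that more compound is tolerated, a lower number that less compound is tolerated. Compound 1 `O=C(CSc1nnnn1-c1cccc2ccccc12)N/N=C/c1cccs1` carries a thiophen-2-yl group on the carbon with a double bond to nitrogen. In this assay compound 1 gives > 316000 nM, which is a limit of the assay and not a number. Compound 2 `O=C(CSc1nnnn1-c1cccc2ccccc12)N/N=C/c1ccc(Cl)cc1` carries a 4-chlorophenyl group instead. Compound 2 likewise reaches only a limit, > 295000 nM, so it stands at the top of what the assay can report. Compound 3 `O=C(CSc1nnnn1-c1cccc2ccccc12)N/N=C/c1ccccc1Cl` carries a 2-chlorophenyl group, and compound 3 gives 69700 nM. The step from compound 1 to compound 2 is a step that the two limits leave unreadable from compound 1 to compound 2. The step from compound 2 to compound 3 is an at least 4.2-fold lower number from compound 2 to compound 3 (0.62 log units; beyond the scatter), and its size is only a bound because of the limit of > 295000 nM in this assay, at which 1 of the 3 values shown sits. The step from compound 1 to compound 3 is an at least 4.5-fold lower number from compound 1 to compound 3 (0.65 log units; beyond the scatter).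

Compound 4 `O=C(CSc1nnnn1-c1cccc2ccccc12)N/N=C/c1ccccc1F` has not yet been measured. It differs from compound 2 by 2-fluorophenyl in place of 4-chlorophenyl on a carbon with a double bond to nitrogen. The step from compound 2 to compound 3 bears on this change most closely, since there too the 4-chlorophenyl gave way to a halogenated phenyl, the 2-chlorophenyl. The step from compound 2 to compound 4 is therefore expected to be an at least 2.4-fold lower number from compound 2 to compound 4 (0.39 log units; beyond the scatter). Compound 4 is estimated at 120000 nM, within a range from 40000 nM to 300000 nM, though fluorine is not chlorine and a value back at the limit cannot be ruled out.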

Compound 4, half-maximal cytotoxic concentration: >= 118000 nM
Compound 4: a limit, no number; the forecaster's own chance of this, stated with the estimate: 35%; the middle value is on the limit's open side.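

Fluoro in place of chloro on an aromatic carbon gives an at least 1.6-fold higher number from compound 3 to compound 4 (0.22 log units; that floor lies within the scatter), and since that floor lies within the usual scatter, compound 4 may or may not share the lower tolerance seen for compound 3. The earlier compounds shown here showed that the 2-chlorophenyl group of compound 3 is tolerated less well than the 4-chlorophenyl group of compound 2, but the 2-fluorophenyl group of compound 4 neither confirms nor breaks that picture in this assay. The steps to compound 4 from compound 1 and from compound 2 cannot be read, because compound 4 ends at a limit and not at a number: the limit of >= 118000 nM in this assay, at which 1 of the 4 values shown sits.

Still open, from the compounds shown here alone, is whether the true value of compound 4 lies close to that of compound 3 or as high as the limits of compound 1 and compound 2, so it remains unsettled whether swapping chloro for fluoro changes anything here. Also open, going by these compounds, is how a 4-fluorophenyl group would compare with the 4-chlorophenyl group of compound 2, and how a phenyl group bearing an amine or a carboxylic acid would fare in this assay.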